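This account rests on a few compounds, and the source may have more. Where it says the series, first, only, none or still open, it means among the compounds named here.

Measured compounds in the series:

- compound 1, `Cc1cc(C)cc(NC(=O)COc2cc(C)nc3ccc(OCc4ccccc4)cc23)c1`, 7.03
- compound 2, `COc1ccc2nc(C)cc(OCC(=O)Nc3ccccc3)c2c1`, 4.28
- compound 3, `COc1ccc2nc(C)cc(OCC(=O)Nc3cc(OC)c(OC)c(OC)c3)c2c1`, 3.95

In a physicochemical assay for lipophilicity, read by HPLC, in phosphate buffer, measured as chromatographic lipophilicity, at pH 7.4 (a lower number here means a more polar compound, a higher number a more lipophilic compound), compound 2 gives 4.28, the second highest of the three numbers. Compound 3 is the nearest, with 3.95, a value that lies beyond the scatter below compound 2. Compound 1 is the furthest, with 7.03, well beyond the scatter above compound 2. Among the measured compounds shown here, no pair of measured compounds differs in a single place, so no measured single step is available for the series.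

Compound 4, `COc1ccc2nc(C)cc(OCC(=O)Nc3ccccn3)c2c1`, has not yet been measured in this assay. It differs from compound 2 in one place: pyridin-2-yl in place of phenyl on an amide-type nitrogen. For the measured compounds named here, with no measured step of this type, the expectation rests on the structures alone. The step from compound 2 to compound 4 in this assay is expected to be downward and larger than the scatter, but modest; the estimated step is a number 0.68 log units lower from compound 2 to compound 4 (beyond the scatter). Compound 4 is accordingly expected to give about 3.6, within a range from 3.1 to 4.1.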

Compound 4, distribution coefficient: 3.49
For compound 4 the middle estimate is 0.11 log units above the measured one; the measured number falls inside the stated range.
By their numbers in this assay, from the lowest: compound 4; then compound 3; then compound 2; then compound 1.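

Pyridin-2-yl in place of phenyl on an amide-type nitrogen gives the first single-place step in the series: in this assay the step reads a number 0.79 log units lower from compound 2 to compound 4 (beyond the scatter) and is modest. The earlier compounds shown here differ in more than one place, so they could not isolate this position, whereas here 6 heavy atoms leave and 6 enter, with 1 nitrogen replacing 1 carbon in the ring and 1 hydrogen-bond acceptor entering. No measurement shown here accounts for the size of this step.

From the compounds shown here alone, it remains open whether the same exchange gives a step of similar size with the other substituents of compound 1 or compound 3. Also open, going by these compounds, is how pyridin-3-yl, pyridin-4-yl or pyrimidin-2-yl would compare with pyridin-2-yl on the same amide-type nitrogen.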